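The source may hold more compounds than are shown below. What is called first, only, known or untested is meant among the compounds shown, and "the series" means these compounds.

Compound 1 `c1cncc(CNCCCCN(C[C@H]2Cc3ccccc3CN2)[C@H]2CCCc3cccnc32)c1` and compound 2 `c1ccc2c(c1)CN[C@@H](CN(CCCCNCC1CCNCC1)[C@H]1CCCc3cccnc31)C2` share one core and were both taken through the same read-out. In a functional assay on cells for agonist activity at C-X-C chemokine receptor type 4 (Homo sapiens), read by fluorescence and calcium flux, with a stated time of 90 s (on this read-out higher numbers stand for an effect only at larger amounts of compound and lower numbers for an effect already at smaller amounts), compound 1 gives only a limit, > 30000 nM. In this assay compound 2 likewise gives only a limit, > 30000 nM. The step that the two limits leave unreadable from compound 1 to compound 2 is unreadable because of the limit of > 30000 nM in this assay, at which 2 of the 2 values shown sit. Compound 3 `O=S1(=O)CCC(CNCCCCN(C[C@H]2Cc3ccccc3CN2)[C@H]2CCCc3cccnc32)CC1` differs from compound 2 by 1,1-dioxothian-4-yl in place of piperidin-4-yl on a saturated chain carbon bound to an amine nitrogen. Among the compounds with values here, no measured step with a readable size bears on this change, so compound 2 offers only its limit as a starting point. Compound 3 is expected to show a step that the limit leaves unreadable from compound 2 to compound 3, that is, none beyond the scatter. Compound 3 is therefore estimated at 40000 nM, with a range from 8000 nM to 200000 nM.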

Compound 3, half-maximal effective concentration: > 30000 nM
Compound 3: no number, only a limit; the forecaster's own chance of this, stated with the estimate: 85%; the middle value does not contradict the limit.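

No step can be read among compound 1, compound 2 and compound 3, because all of them stop at the same limit: the limit of > 30000 nM in this assay, at which 3 of the 3 values shown sit. The compounds shown leave open whether pyridin-3-yl, piperidin-4-yl and 1,1-dioxothian-4-yl differ at all in this assay.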